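This account rests on a few compounds, and the source may have more. Where it says the series, first, only, none or still open, it means among the compounds named here.

Measured in a functional assay on HepG2 cells (Homo sapiens) for cytotoxicity, read by MTT assay, with a stated time of 24 h; a lower number here means a stronger inhibitor, a higher number a weaker inhibitor:
Compound 1 `CN1C/C(=C\c2ccc(C#N)cc2)C(=O)/C(=C/c2ccccc2F)C1`: 590 nM
Compound 2 `COc1cc(/C=C2\CN(C)C/C(=C\c3cc(OC)c(OC)c(OC)c3)C2=O)cc(OC)c1`: 890 nM

These two numbers lie within the usual scatter of each other, so compound 2 cannot be told apart from compound 1 in this assay. The next compound, compound 3 `COc1cc(/C=C2\CN(C)C/C(=C\c3ccc(Cl)cc3Cl)C2=O)cc(OC)c1OC`, has not yet been measured. It differs from compound 2 in one place: 2,4-dichlorophenyl in place of 3,5-dimethoxyphenyl on a double-bonded chain carbon bound to a double-bonded ring carbon. In words, 2,4-dichlorophenyl stands in place of 3,5-dimethoxyphenyl on a double-bonded chain carbon bound to a double-bonded ring carbon.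

Going by the values given here, no measured pair shows a single change, so the data give no direct guide to this step. Compound 1 carries no methoxy groups and gives 590 nM, within the scatter of compound 2, so no shift beyond the scatter is expected. The expected step is a 1.4-fold lower number from compound 2 to compound 3 (0.14 log units; within the scatter). For compound 3 the estimated value is 650 nM, with an expected range of 250 nM to 1700 nM.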

Compound 3, half-maximal inhibitory concentration: 8800 nM
The estimate for compound 3 lay 14-fold (1.13 log units) below the measured number; the whole stated range lies below it.
By their numbers in this assay, from the lowest: compounds 1 and 2 (each within the scatter of the next); then compound 3.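

In this assay, putting 2,4-dichlorophenyl in place of 3,5-dimethoxyphenyl on a double-bonded chain carbon bound to a double-bonded ring carbon gives a 9.9-fold higher number from compound 2 to compound 3 (1.00 log units; beyond the scatter), so compound 3 is a weaker inhibitor than compound 2. Compounds 1 and 2 differ in more than one place and could not show that this position responds to a single change of group. No measurement here explains why the number rises.

This change removes two methoxy groups and adds two chlorines in one step, so it remains open which part accounts for the rise. A plain phenyl group at this position, or a phenyl group carrying one chlorine, would help separate the two.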